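The source may report more compounds than this note shows. Statements on the series, on what has been measured and on what is new or still open speak of the compounds shown alone.

The measured compounds:

compound 1, `Cc1ncnc2c1c(-c1cccs1)cn2[C@@H]1O[C@H](CO)[C@@H](O)[C@H]1O`: > 20000 nM
compound 2, `COc1ncnc2c1c(-c1cccs1)cn2[C@@H]1O[C@H](CO)[C@@H](O)[C@H]1O`: 80 nM
compound 3, `O=c1[nH]cnc2c1c(-c1cc3ccccc3o1)cn2[C@@H]1O[C@H](CO)[C@@H](O)[C@H]1O`: > 20000 nM

These values come from a functional assay on HCT-116 cells (Homo sapiens), read by MTT assay, with a stated time of 72 h; on this read-out higher numbers stand for weaker inhibition and lower numbers for stronger inhibition. For compound 1 the value is a limit of this assay, not a number. For compound 3 the value is likewise only a limit. Compound 1 therefore stands with compound 3 at the limit of > 20000 nM in this assay, at which 2 of the 3 values shown sit, while compound 2 is the only one of the three with a numeric value. Within the data shown here, the single step between compounds that differ in one place is an at least 250-fold lower number from compound 1 to compound 2 (2.39 log units; beyond the scatter), a change of the group on the core rather than of the five-membered ring attached to it.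

Compound 4, `Cc1ncnc2c1c(-c1ccsc1)cn2[C@@H]1O[C@H](CO)[C@@H](O)[C@H]1O`, differs from compound 1 by thiophen-3-yl in place of thiophen-2-yl on an aromatic carbon. The methyl on the core is unchanged. Among the measured compounds shown here, no measured step shows this change: the one step available concerns methoxy in place of methyl, a different place. For the measured compounds named here, compound 1 itself sits at the limit, and no measured step suggests that moving the attachment of the thiophene alone would bring the value into the measured range. Compound 4 is therefore expected to remain at the limit, a step of a number no higher from compound 1 to compound 4 (the limit leaves the size open), with no change beyond the scatter expected. The estimate for compound 4 is 20000 nM, between 5000 nM and 100000 nM.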

Compound 4, half-maximal inhibitory concentration: 460 nM
Beside the measured number, compound 4's estimate is 43-fold (1.64 log units) above it; the whole stated range lies above it.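

In this assay, the step of an at least 43-fold lower number from compound 1 to compound 4 (1.63 log units; beyond the scatter) shows that the point at which the thiophene is attached to the shared core matters on its own: the two compounds have the same atoms, joined differently, and the methyl on the core stays in place. Among these compounds, earlier, the only readable step was a change of the group on the core, an at least 250-fold lower number from compound 1 to compound 2 (2.39 log units; beyond the scatter), so this result adds a second place where a single change moves the value, and it shows that a methyl on the core does not by itself hold a compound at the limit. The exact size of the new step stays open, since the value of compound 1 is a limit and not a number: the limit of > 20000 nM in this assay, at which 2 of the 4 values shown sit.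

On these data alone, what thiophen-3-yl does when methoxy stands on the core in place of methyl remains open, and so does whether the attachment point matters as much there. Also open, as far as these compounds go, is how a phenyl group at this position, or an amine such as dimethylamino on the core in place of the methyl, would read in this assay.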